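The compounds below may be only part of what the source reports. "The series", "measured", "known", "first", "only" and "open" are said of these compounds alone.

Measured compounds:
compound 1, `Cc1ccc(Cn2c(/C=C3\SC(=S)N(CC(=O)O)C3=O)nc3cc(Cl)ccc32)cc1`, 21400 nM in a functional assay on HeLa cells (Homo sapiens) for cytotoxicity, read by MTT assay, with a stated time of 48 h; a higher number here means a weaker inhibitor, a lower number a stronger inhibitor
compound 2, `Cc1ccc(Cn2c(/C=C3\SC(=S)N(CC(=O)O)C3=O)nc3ccc(Cl)cc32)cc1`, 11000 nM in this assay
compound 3, `Cc1ccc(Cn2c(/C=C3\SC(=S)N(CC(=O)O)C3=O)nc3cc(F)ccc32)cc1`, 2380 nM in this assay

Compound 1 and compound 3 differ in one place: fluoro in place of chloro on an aromatic carbon. This change gives a 9.0-fold lower number from compound 1 to compound 3 (0.95 log units; beyond the scatter). Compound 2 shares its atoms with compound 1 but has them joined differently; the difference between the two cores is not broken down here, and compound 2 and compound 1 give values within the scatter of each other.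

The unmeasured compound 4, `Cc1ccc(Cn2c(/C=C3\SC(=S)N(CC(=O)O)C3=O)nc3ccc(F)cc32)cc1`, is related to compound 2 in the same way: fluoro in place of chloro on an aromatic carbon. Since the place is described in the same words in both pairs, the same change is made on a different core. For the measured compounds named here, a step of similar size is expected from compound 2 to compound 4, a 7.3-fold lower number from compound 2 to compound 4 (0.87 log units; beyond the scatter), resting on the single step seen for compound 1 to compound 3, a 9.0-fold lower number from compound 1 to compound 3 (0.95 log units; beyond the scatter); with only one prior example, the expected range is kept wide. Compound 4 is therefore estimated at 1500 nM in this assay, between 500 nM and 6000 nM.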

Compound 4, half-maximal inhibitory concentration: 3920 nM
Beside the measured number, compound 4's estimate is 2.6-fold (0.42 log units) below it; the range from low to high includes it.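

Replacing chloro with fluoro lowers the number again in this assay, with a 2.8-fold lower number from compound 2 to compound 4 (0.45 log units; beyond the scatter), so the direction of the change carries from one core to the other in these two pairs. The size of the step does not carry over, and the gap between the two steps is larger than repeat measurements would explain: the same change on two cores in this assay, a 9.0-fold lower number (0.95 log units; beyond the scatter) from compound 1 to compound 3 and a 2.8-fold lower number (0.45 log units; beyond the scatter) from compound 2 to compound 4, 3.2-fold (0.51 log units) apart, beyond the scatter of two such steps These pairs therefore show that the core in which the change is made can alter how much it matters, but they do not show why, and two pairs cannot establish a rule for any other core.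

The compounds shown leave open what a bromo, methoxy or nitrile group, or a plain hydrogen, would give in place of the halogen on either core. They also leave open whether the step between the two cores would look the same with any of those groups.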